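The source may hold more compounds than are shown below. What is called first, only, known or untested is meant among the compounds shown, and "the series" means these compounds.

Measured so far:
Compound 1 `CNC(=O)c1cc(Oc2ccc(C3=NNC(c4ccc(F)cc4Cl)C3)cc2)ccn1` gives 11500 nM
Compound 2 `CNC(=O)c1cc(Oc2ccc(C3=NNC(c4ccc([N+](=O)[O-])cc4)C3)cc2)ccn1` gives > 50000 nM which is a limit

Both values come from a functional assay on HepG2 cells (Homo sapiens) for cytotoxicity, read by MTT assay, with a stated time of 72 h; on this read-out higher numbers stand for weaker inhibition and lower numbers for stronger inhibition. Compound 2 stands at the limit of > 50000 nM in this assay, at which 1 of the 2 values shown sits, so it offers a limit and no number of its own.

Compound 3 `CNC(=O)c1cc(Oc2ccc(C3=NNC(c4cccc([N+](=O)[O-])c4)C3)cc2)ccn1` differs from compound 2 in one place, with 3-nitrophenyl in place of 4-nitrophenyl on a saturated ring carbon. For the measured compounds named here, the one measured step that bears on this is an at least 4.3-fold higher number from compound 1 to compound 2 (0.63 log units; beyond the scatter), with 4-nitrophenyl in place of 2-chloro-4-fluorophenyl. Going by the values given here, that step compares a nitrophenyl group with a halogenated phenyl group, and no measured pair compares the two nitrophenyl groups. It therefore gives no size for the present change, and the expectation is for compound 3 to remain close to the limit of compound 2.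

No step beyond the scatter is expected in this assay, and the expected change is an at least 1.4-fold lower number from compound 2 to compound 3 (0.15 log units; that floor lies within the scatter). For compound 3 the estimated value is 35000 nM, with an expected range from 12000 nM to 60000 nM.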

Compound 3, half-maximal inhibitory concentration: 26500 nM
Beside the measured number, compound 3's estimate is 1.3-fold (0.12 log units) above it; low and high end bracket the measured number.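

In this assay, 3-nitrophenyl in place of 4-nitrophenyl on the saturated ring carbon gives an at least 1.8-fold lower number from compound 2 to compound 3 (0.27 log units; that floor lies within the scatter), so this change has a floor and no measured size, and no real difference between the two nitrophenyl groups can be claimed. Compound 2 carries a limit and not a number of its own: the limit of > 50000 nM in this assay, at which 1 of the 3 values shown sits. What is new is a nitrophenyl group with a real number at this position: 3-nitrophenyl in place of 2-chloro-4-fluorophenyl gives a 2.3-fold higher number from compound 1 to compound 3 (0.36 log units; beyond the scatter), a modest step beyond the scatter that holds for this one pair.

The compounds shown leave open how an unsubstituted phenyl, a 4-fluorophenyl, a 2-chlorophenyl or a 3-aminophenyl would read on this ring carbon, and so whether the gap in this assay follows the chlorine, the fluorine or the nitro group. On these data alone, how far compound 2 lies past its limit also stays unknown, which leaves the true size of the step between the two nitrophenyl groups undetermined.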